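A few compounds are considered here, and "the series" means these few. Any claim that something is new, unique, unknown or untested is made for them only; others in the source may bear on it.

Series notes. In an in vitro functional assay on cells for agonist activity at Bombesin receptor subtype-3 (Mus musculus), read by luminescence and calcium flux (on this read-out higher numbers stand for an effect only at larger amounts of compound and lower numbers for an effect already at smaller amounts), compound 3 `O=C(O)c1ccccc1-c1ccc(CCc2ncc(Cc3ccc(F)cc3)[nH]2)cc1` gives 50 nM and stands second highest of the three numbers. Compound 1 `O=C(O)c1ccccc1-c1ccc(CCc2ncc(CCc3ccccc3)[nH]2)cc1` gives 174 nM and compound 2 `O=C(O)c1ccccc1-c1ccc(CCc2ncc(Cc3ccccc3Cl)[nH]2)cc1` gives 22 nM; the steps of a 3.5-fold lower number from compound 1 to compound 3 (0.54 log units; beyond the scatter) and a 2.3-fold higher number from compound 2 to compound 3 (0.36 log units; beyond the scatter) place compound 3 between them, and a 7.9-fold lower number from compound 1 to compound 2 (0.90 log units; beyond the scatter) spans the whole range. Compound 4 `O=C(O)c1ccccc1-c1ccc(CCc2ncc(CC3CCCC3)[nH]2)cc1` differs from compound 3 by cyclopentyl in place of 4-fluorophenyl on a saturated chain carbon bound to an aromatic carbon. Among the measured compounds shown here, no measured step swaps an aromatic ring for a non-aromatic one; the three steps only show that the group on this saturated chain carbon shifts the number by modest amounts. A modest step in either direction is therefore plausible, with a rise in the number judged somewhat more likely. Compound 4 is estimated at 120 nM, range 30 nM to 500 nM. The step of a 2.4-fold higher number from compound 3 to compound 4 (0.38 log units; beyond the scatter) is the expected outcome.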

Compound 4, half-maximal effective concentration: 7.9 nM
Compound 4: middle estimate off by 15-fold (1.18 log units), on the high side, outside the stated range (below it).
By their numbers in this assay, from the lowest: compound 4; then compound 2; then compound 3; then compound 1.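

In this assay the steps of a 6.3-fold lower number from compound 3 to compound 4 (0.80 log units; beyond the scatter) and a 2.8-fold lower number from compound 2 to compound 4 (0.44 log units; beyond the scatter) and a 22-fold lower number from compound 1 to compound 4 (1.34 log units; beyond the scatter) put cyclopentyl at the low end of the four numbers. On a saturated chain carbon bound to an aromatic carbon, an aromatic ring is therefore not required for a low number, and in this set the non-aromatic ring outperforms each aromatic group shown. Nothing available explains this shift.

On these data alone, whether any ring is needed remains open, since an open chain such as isobutyl would test this. Also open, as far as these compounds go, is how cyclohexyl or a ring carrying an amine would compare with cyclopentyl.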